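The source may hold more compounds than are shown below. What is called first, only, known or untested is meant among the compounds shown, and "the series" means these compounds.

Three compounds share a core and differ in the chain that carries the amine. Compound 1 `O=c1cc(-c2ccccc2)oc2cccc(OCCCCN3CCC(O)CC3)c12` gives 177 nM in an assay on isolated protein (Cavia porcellus) with Sigma non-opioid intracellular receptor 1 (Homo sapiens) as the target, read by radioligand binding; a higher number here means a weaker inhibitor, a lower number a stronger inhibitor. For the measured compounds named here, compound 2 `O=c1cc(-c2ccccc2)oc2cccc(OCCCCCCCN3CCC(O)CC3)c12` gives 65 nM in this assay, and the only single-point step among the measured compounds is a 2.7-fold lower number from compound 1 to compound 2 (0.44 log units; beyond the scatter). Compound 3 `CN(C)CCCCCCCCOc1ccc2oc(-c3ccccc3)cc(=O)c2c1` gives 143 nM in this assay, the second highest of the three numbers: it sits within the scatter of compound 1 and beyond the scatter of compound 2, which has the lower number.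

Compound 4 `O=c1cc(-c2ccccc2)oc2ccc(OCCCCCCN3CCC(O)CC3)cc12` is not yet measured. The change from compound 3 is 4-hydroxypiperidin-1-yl in place of 2-(dimethylamino)ethyl on a saturated chain carbon, six bonds along the chain from an oxygen on an aromatic ring. Going by the values given here, no measured step swaps the amine in this way, so the only guide is the step from compound 1 to compound 2, which shows that a longer chain ending in the hydroxypiperidine reached the lowest number in the set. Compound 4 carries that same hydroxypiperidine on a chain close to that of compound 2, and compound 2 is the most direct comparison even though the two differ by one chain carbon without a measured step between them. The expected step is a 1.6-fold lower number from compound 3 to compound 4 (0.20 log units; within the scatter), a modest move toward the value of compound 2. Compound 4 is therefore estimated at 90 nM in this assay, within a range of 40 nM to 200 nM.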

Compound 4, half-maximal inhibitory concentration: 121 nM
Compound 4: middle estimate off by 1.3-fold (0.13 log units), on the low side, within the range that was stated.
By their numbers in this assay, from the lowest: compounds 2, 4, 3 and 1 (each within the scatter of the next, the first and the last beyond it).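

For the compounds shown here, the step of a 1.2-fold lower number from compound 3 to compound 4 (0.07 log units; within the scatter) in this assay gives the first reading of a change at the amine end of the chain, since the earlier step concerned only chain length. On a saturated chain carbon, six bonds along the chain from an oxygen on an aromatic ring, replacing 2-(dimethylamino)ethyl with 4-hydroxypiperidin-1-yl brings in a six-membered non-aromatic ring and a hydrogen-bond donor, yet the two numbers stay within the scatter, so this pair shows no measurable difference between these two amine ends. No supporting evidence bears on why the two numbers stay so close.

As far as these compounds go, it remains open whether the chain-length step seen between compound 1 and compound 2 would carry over to the shared core with the chain attached as in compound 3 and compound 4, where a longer or shorter chain ending in 4-hydroxypiperidin-1-yl would test it. From the compounds shown here alone, how other amines would read on the chain of compound 4, such as an unsubstituted piperidine, a morpholine or a pyrrolidine, also remains open.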